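Phenyl in Place of Thiophene on the Shared Core

This account rests on a few compounds, and the source may have more. Where it says the series, first, only, none or still open, it means among the compounds named here.

Compound 3 `N#Cc1c(-c2cccs2)nc2c(c(-c3ccccc3)nn2-c2ccccc2)c1-c1ccc(O)cc1` reached only the limit of a functional assay on CCRF-CEM cells (Homo sapiens) for antiproliferative activity, read by resazurin assay, with a stated time of 72 h (a lower number here means a stronger inhibitor, a higher number a weaker inhibitor), giving > 25000 nM. Among its relatives, compound 1 `N#Cc1c(-c2ccco2)nc2c(c(-c3ccccc3)nn2-c2ccccc2)c1-c1ccc(O)cc1` gives 23900 nM and compound 2 `COc1ccc(-c2nc3c(c(-c4ccccc4)nn3-c3ccccc3)c(-c3ccc(O)cc3)c2C#N)cc1` gives 6700 nM in this assay. The measured steps show an at least 1.0-fold higher number from compound 1 to compound 3 (0.01 log units; that floor lies within the scatter), whereas a 3.6-fold lower number from compound 1 to compound 2 (0.55 log units; beyond the scatter) and an at least 3.7-fold higher number from compound 2 to compound 3 (0.57 log units; beyond the scatter). Compound 4 `N#Cc1c(-c2ccccc2)nc2c(c(-c3ccccc3)nn2-c2ccccc2)c1-c1ccc(O)cc1` differs from compound 3 by phenyl in place of thiophen-2-yl on an aromatic carbon. The step from compound 1 to compound 2 suggests that a six-membered ring at this place can lower the number, but phenyl lacks the methoxy of compound 2, so only a modest step is expected: an at least 1.6-fold lower number from compound 3 to compound 4 (0.22 log units; that floor lies within the scatter). Compound 4 is therefore estimated at 15000 nM, between 5000 nM and 40000 nM, with a fair chance that this assay again reports only a limit.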

Compound 4, half-maximal inhibitory concentration: 33400 nM
For compound 4 the middle estimate is 2.2-fold (0.35 log units) below the measured one; measured number inside the range.
By their numbers in this assay, from the lowest: compound 2; then compounds 1 and 4 (each within the scatter of the next).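

In this assay, hydrogen in place of methoxy on the six-membered ring gives a 5.0-fold higher number from compound 2 to compound 4 (0.70 log units; beyond the scatter), so at this place a six-membered ring alone does not carry the lower number of compound 2. Phenyl and furan-2-yl are not told apart here, with a 1.4-fold higher number from compound 1 to compound 4 (0.15 log units; within the scatter). Compound 3 gives only a limit, and its step to compound 4 cannot be read: the limit of > 25000 nM in this assay, at which 1 of the 4 values shown sits.

The compounds shown do not tell whether the methoxy is special. As far as these compounds go, an amine, a fluorine or a longer ethoxy chain in its place on the phenyl ring remains untested among them.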